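The source may hold more compounds than are shown below. What is called first, only, known or untested is meant among the compounds shown, and "the series" means these compounds.

Among the measured compounds shown here, in a functional assay on PC-3 cells (Homo sapiens) for cytotoxicity, read by sulforhodamine B assay (a lower number here means a stronger inhibitor of growth, a higher number a weaker inhibitor of growth), compound 1 `COc1cccc(OC)c1OCCNCCOc1ccccc1OCc1ccccc1` gives 26900 nM, the highest number among the three compounds measured so far, which makes it the weakest inhibitor of growth in this set. Compound 2 `COc1cccc(OC)c1OCCNCCOc1ccccc1OCc1ccc(Cl)cc1` gives 2400 nM, and compound 3 `COc1cccc(OC)c1OCCNCCOc1ccccc1OCc1cccc([N+](=O)[O-])c1` gives 13200 nM. Compound 4 `COc1cccc(COc2ccccc2OCCNCCOc2c(OC)cccc2OC)c1` has not been measured yet. It differs from compound 1 by methoxy in place of hydrogen on an aromatic carbon. For the measured compounds named here, two measured steps bear on this change, since each of them also swaps one hydrogen of compound 1 for a new substituent: an 11-fold lower number from compound 1 to compound 2 (1.05 log units; beyond the scatter), and a 2.0-fold lower number from compound 1 to compound 3 (0.31 log units; beyond the scatter). Both additions lowered the number, one by a large margin and one by a modest one. Methoxy is a third kind of group, so the size of its step cannot be read directly from either of these, but a lowering beyond the scatter appears more likely than no change, and the modest case seems the safer guide. Compound 4 is therefore expected to give 12000 nM, within a range from 4000 nM to 35000 nM. This estimate amounts to an expected 2.2-fold lower number from compound 1 to compound 4 (0.35 log units; beyond the scatter).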

Compound 4, concentration for 50% growth inhibition: 2500 nM
Estimate against measurement, compound 4: 4.8-fold (0.68 log units) above, and the stated range ends above it.
By their numbers in this assay, from the lowest: compounds 2 and 4 (each within the scatter of the next); then compound 3; then compound 1.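

In this assay, methoxy on this ring carbon, meta to a large group, gives an 11-fold lower number from compound 1 to compound 4 (1.03 log units; beyond the scatter) and so turns out to be a large change, not a modest one. Replacing 4-chlorophenyl with 3-methoxyphenyl gives a 1.0-fold higher number from compound 2 to compound 4 (0.02 log units; within the scatter) and leaves these two groups indistinguishable in this assay, even though one carries chloro and the other methoxy. Nitro stands apart from both, since methoxy in its place gives a 5.3-fold lower number from compound 3 to compound 4 (0.72 log units; beyond the scatter) in this assay, so a large lowering does not follow from adding just any group to this ring.

Nothing here gives a measured reason for these differences. Still open, on these data alone, is how a hydroxyl, an amine or a fluorine would fare on this carbon, and whether methoxy on the other carbons of this ring would give a step of the same size.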